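The source may hold more compounds than are shown below. What is called first, only, known or untested is meant among the compounds shown, and "the series" means these compounds.

Compound 1 `Cc1nc(COc2ccc(C(=O)N3CCC[C@@H]3c3ccc4c(c3)OCCO4)cc2)cs1` gives > 100000 nM in an assay on CHO cells for displacement of a labelled ligand from Orexin/Hypocretin receptor type 1 (Homo sapiens), read by radioligand binding, with a stated time of 2 h (on this read-out higher numbers stand for weaker inhibition and lower numbers for stronger inhibition), which is a limit of the assay and not a number.
Compound 2 `Cc1cc([C@@H]2CCCCN2C(=O)c2ccc(-c3cc[nH]n3)cc2)no1` gives > 100000 nM in this assay, again a limit of the assay.
Compound 3 `Cc1nc(-c2ccc(Cl)c(S(=O)(=O)N3CCC[C@@H](C(=O)N4CCc5ccccc54)C3)c2)no1` gives > 100000 nM in this assay, also a limit of the assay.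

Compound 1 therefore stands only at a limit in this assay, and the other two measured compounds stand at the same limit, so none of the three can be placed above or below another. This is summed up by the limit of > 100000 nM in this assay, at which 3 of the 3 values shown sit. No pair of these compounds differs in a single place, so no measured step is available to judge the size of a change.

Compound 4 `O=C(c1ccc(OCc2cn3ccccc3n2)cc1)N1CCC[C@@H]1c1ccc2c(c1)OCCO2` has not yet been measured in this assay. It differs from compound 1 in one place: a group of 9 heavy atoms (7 carbon, 2 nitrogen; one five-membered aromatic ring with 2 hetero atoms, one six-membered aromatic ring with 1 hetero atom) in place of a group of 6 heavy atoms (4 carbon, 1 nitrogen, 1 sulfur; one five-membered aromatic ring with 2 hetero atoms), on a saturated chain carbon bound to an oxygen on an aromatic ring. Among the compounds with values here, with every measured value sitting at the limit, there is no measured step to lean on, and the expectation for the step from compound 1 to compound 4 can only be a guess. The step of an at least 1.6-fold lower number from compound 1 to compound 4 (0.22 log units; that floor lies within the scatter) is expected to lie toward stronger inhibition, if anywhere, but the chance that compound 4 also stops at the limit is judged high. For compound 4 the estimate in this assay is 60000 nM, with a range from 8000 nM to 100000 nM.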

Compound 4, half-maximal inhibitory concentration: > 100000 nM
Compound 4: no number, only a limit; the forecaster's own chance of this, stated with the estimate: 65%; middle value at least 1.6-fold (0.22 log units) from the limit.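

Compound 1 and compound 4 both stop at a limit of the assay and not at a number, so no step can be read between them, and the four compounds still cannot be ranked: the limit of > 100000 nM in this assay, at which 4 of the 4 values shown sit. The compounds shown leave open which structure, if any, would give an actual number in this assay and so show how large the effect of a change is.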